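The compounds below may be only part of what the source reports. "The series", "measured", "known", "first", "only" and "open" are said of these compounds alone.

Measured so far in a functional assay on HT-29 cells (Homo sapiens) for antiproliferative activity, read by MTT assay, with a stated time of 72 h; a higher number here means a weaker inhibitor, a lower number a stronger inhibitor:
compound 1 `COc1ccc(-n2c(=O)c(C(=O)Nc3ccc(Oc4ccnc5[nH]ccc45)cc3)cc3cccnc32)cc1`, 1260 nM
compound 2 `O=C(Nc1ccc(Oc2ccnc3[nH]ccc23)cc1)c1cc2cccnc2n(-c2ccc(F)c(Cl)c2)c1=O`, 560 nM
compound 3 `COc1ccc(-n2c(=O)c(C(=O)Nc3ccc(Oc4ccnc5c4ccn5C)cc3)cc3cccnc32)cc1`, 2050 nM

Compound 2 differs from compound 1 by 3-chloro-4-fluorophenyl in place of 4-methoxyphenyl on an aromatic nitrogen; this gave a 2.3-fold lower number from compound 1 to compound 2 (0.35 log units; beyond the scatter). Compound 3 differs from compound 1 by methyl in place of hydrogen on an aromatic nitrogen; this gave a 1.6-fold higher number from compound 1 to compound 3 (0.21 log units; within the scatter). Compound 4 `Cn1ccc2c(Oc3ccc(NC(=O)c4cc5cccnc5n(-c5ccc(F)c(Cl)c5)c4=O)cc3)ccnc21` is not yet measured; it differs from compound 3 by 3-chloro-4-fluorophenyl in place of 4-methoxyphenyl on an aromatic nitrogen, and the place of change is the same, word for word, as that between compound 1 and compound 2, so the change is the same one, made on the core of compound 3 rather than on the core of compound 1. The expectation for compound 4 rests on one step only, that from compound 1 to compound 2, and is therefore estimated as a 2.3-fold lower number from compound 3 to compound 4 (0.36 log units; beyond the scatter) in this assay. Compound 4 is expected to give about 900 nM, plausibly between 400 nM and 2000 nM.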

Compound 4, half-maximal inhibitory concentration: 1210 nM
Compound 4: the middle estimate sits 1.3-fold (0.13 log units) below what was measured, and the stated range covers the measured number.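

In this assay, 3-chloro-4-fluorophenyl in place of 4-methoxyphenyl gives a 1.7-fold lower number from compound 3 to compound 4 (0.23 log units; within the scatter), in agreement with the step on the other core: the same change on two cores in this assay, a 2.3-fold lower number (0.35 log units; beyond the scatter) from compound 1 to compound 2 and a 1.7-fold lower number (0.23 log units; within the scatter) from compound 3 to compound 4, 1.3-fold (0.12 log units) apart, within the scatter of two such steps. Methyl in place of hydrogen on the aromatic nitrogen gives a 2.2-fold higher number from compound 2 to compound 4 (0.33 log units; beyond the scatter), and this also agrees with its earlier step: the same change on two cores in this assay, a 1.6-fold higher number (0.21 log units; within the scatter) from compound 1 to compound 3 and a 2.2-fold higher number (0.33 log units; beyond the scatter) from compound 2 to compound 4, 1.3-fold (0.12 log units) apart, within the scatter of two such steps. The two changes therefore carry over between these cores in this set of four compounds, although the aryl step on the core of compound 3 lies within the scatter on its own, and nothing here shows that either change would carry to a further core.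

As far as these compounds go, it remains open whether a longer chain in place of the methyl, or an aryl group bearing an amine or a carboxylic acid, would follow the same steps.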